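This account rests on a few compounds, and the source may have more. Where it says the series, first, only, none or still open, it means among the compounds named here.

Measured in a functional assay on EBC-1 cells (Homo sapiens) for antiproliferative activity, with a stated time of 72 h; a lower number here means a stronger inhibitor, a higher number a weaker inhibitor:
- compound 1 `OCCn1cc(-c2cc(F)c3ncc(Cc4ccc5ncccc5c4)n3c2)cn1`: 0.34 nM
- compound 2 `Fc1cc(-c2cnn(C3CCNCC3)c2)cn2c(Cc3ccc4ncccc4c3)cnc12`: 1.46 nM

Going by the values given here, compound 1 holds the lower of the two numbers in this assay, and compound 2 is its only neighbour. The next candidate is compound 3 `Fc1cc(F)cc(-c2cc(F)c3ncc(Cc4ccc5ncccc5c4)n3c2)c1`, which keeps the core of compound 1 and exchanges one group: 3,5-difluorophenyl in place of 1-(2-hydroxyethyl)-1H-pyrazol-4-yl on an aromatic carbon. The exchange sits on an aromatic carbon, meta to a fluoro group.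

Among the compounds with values here, only one measured step bears on this: a 4.3-fold higher number from compound 1 to compound 2 (0.63 log units; beyond the scatter). That modest step changes just the substituent on an aromatic nitrogen and leaves the five-membered aromatic ring in place, so it is an indirect guide. Within the data shown here, no measured compound shows what happens when that ring is lost altogether. Among the measured compounds shown here, the one change measured so far away from compound 1 raised the number, so a higher number is expected in this assay, of similar or somewhat larger size. The expected change is a 7.4-fold higher number from compound 1 to compound 3 (0.87 log units; beyond the scatter). For compound 3 the estimate is 2.5 nM, with an expected range from 0.5 nM to 12 nM.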

Compound 3, half-maximal inhibitory concentration: 790 nM
Compound 3: the middle estimate sits 320-fold (2.50 log units) below what was measured; the measured number lies above the stated range.
By their numbers in this assay, from the lowest: compound 1; then compound 2; then compound 3.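

In this assay, a 2300-fold higher number from compound 1 to compound 3 (3.37 log units; beyond the scatter), a far larger step than a 4.3-fold higher number from compound 1 to compound 2 (0.63 log units; beyond the scatter). The aromatic carbon therefore tolerates a new substituent on the aromatic nitrogen of the five-membered ring far better than this exchange of the whole ring, at least across these three compounds. The group that leaves and the group that enters both count 8 heavy atoms, so heavy-atom count does not separate them, and nothing measured here accounts for the size of the step.

The exchange changes several things at once: the five-membered aromatic ring with 2 hetero atoms becomes a six-membered aromatic ring of carbon only, the hydrogen-bond donors and acceptors of the leaving group are absent from the entering one, and two fluorines appear, so the compounds shown cannot assign the step to any one of these. As far as these compounds go, a pyridin-3-yl ring, an unsubstituted phenyl or a phenyl carrying a 2-hydroxyethyl chain would help separate these changes, and it remains open whether any six-membered aromatic ring at this carbon can come close to compound 1.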